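The source may hold more compounds than are shown below. What is called first, only, known or untested is meant among the compounds shown, and "the series" means these compounds.

In a functional assay (aorta) with Oryctolagus cuniculus as the target (on this read-out lower numbers stand for stronger inhibition and higher numbers for weaker inhibition), compound 3 `CC(C)c1cnc(-c2nn(Cc3ccccc3F)c3ncccc23)nc1N` gives 207000 nM, the lower of the two single numbers shown, with compound 2 `CCc1cnc(-c2nn(Cc3ccccc3F)c3ncccc23)nc1N` nearest at 272000 nM. Compound 1 `Nc1ccnc(-c2nn(Cc3ccccc3F)c3ncccc23)n1` gives 270 nM; 265000 nM (2 entries) in this assay, two entries that lie far apart (the several entries of compound 1 in this assay, 270 nM; 265000 nM (2 entries)), so no single number is set for it. Compound 4 `CCCCc1cnc(-c2nn(Cc3ccccc3F)c3ncccc23)nc1N` differs from compound 3 by butyl in place of isopropyl on an aromatic carbon. Among the measured compounds shown here, the only measured step along the same chain, a 1.3-fold lower number from compound 2 to compound 3 (0.12 log units; within the scatter), stayed within the scatter, so a further lengthening of that chain is expected to bring no change beyond the scatter in this assay: the expected step is a 1.0-fold lower number from compound 3 to compound 4 (0.01 log units; within the scatter). Compound 4 is therefore estimated at 200000 nM, with a likely range from 60000 nM to 600000 nM.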

Compound 4, half-maximal inhibitory concentration: 218000 nM
Compound 4: middle estimate off by 1.1-fold (0.04 log units), on the low side; low and high end bracket the measured number.
By their numbers in this assay, from the lowest: compounds 3, 4 and 2 (each within the scatter of the next).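

In this assay, butyl on this aromatic carbon, ortho to an amino group, changes little: a 1.1-fold higher number from compound 3 to compound 4 (0.02 log units; within the scatter), and a 1.2-fold lower number from compound 2 to compound 4 (0.10 log units; within the scatter). The earlier step covered only ethyl and isopropyl, whereas this one adds an unbranched butyl chain. Across compounds 2, 3 and 4, neither chain length nor branching moves the number beyond the scatter.

As far as these compounds go, whether an amine or a carboxylic acid on this carbon would behave differently stays open. Whether these chains differ from hydrogen also stays open, as compound 1, which carries hydrogen there, has no single number: the several entries of compound 1 in this assay, 270 nM; 265000 nM (2 entries)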